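The compounds below may be only part of what the source reports. "The series", "measured", "known", "first", "only" and "open" are said of these compounds alone.

Measured in a functional assay for inhibition, with Sus scrofa as the target; on this read-out higher numbers stand for weaker inhibition and lower numbers for stronger inhibition:
- compound 1 `Cn1nc(O[C@@H]2c3cc(C#N)ccc3OC(C)(C)[C@H]2O)ccc1=O`: 50 nM
- compound 2 `CC1(C)Oc2ccc(C#N)cc2[C@@H](On2ccccc2=O)[C@]1(C)O`: > 100000 nM (a limit, not a number)
- compound 3 `Cn1nc(O[C@@H]2c3cc(C#N)ccc3OC(C)(C)[C@@]2(C)O)ccc1=O`: 30 nM

Compound 2 sits at the weak end of these results, and its > 100000 nM is a limit of the assay rather than a number. (the limit of > 100000 nM in this assay, at which 1 of the 3 values shown sits).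

Compound 4 `CC1(C)Oc2ccc(C#N)cc2[C@@H](n2nc(N)ccc2=O)[C@]1(C)O` is still unmeasured. It differs from compound 2 at one place: a group of 8 heavy atoms (4 carbon, 3 nitrogen, 1 oxygen; one six-membered aromatic ring with 2 hetero atoms) in place of a group of 8 heavy atoms (5 carbon, 1 nitrogen, 2 oxygen; one six-membered aromatic ring with 1 hetero atom), on a saturated ring carbon.

Going by the values given here, one measured step bears on this change: an at least 3300-fold lower number from compound 2 to compound 3 (3.52 log units; beyond the scatter). There, a group with one six-membered aromatic ring with 2 hetero atoms also replaced one with a ring containing 1 hetero atom. Compound 4 now brings in such a ring too, although the group is not the same as in compound 3, and it stands on a saturated ring carbon. The earlier step is therefore only a loose guide.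

Given compound 3 at 30 nM, a large move to a lower number in this assay is expected, meaning stronger inhibition, though probably not as far as compound 3 reached: an at least 200-fold lower number from compound 2 to compound 4 (2.30 log units; beyond the scatter).

For compound 4 the estimated value is 500 nM, with an expected range of 30 nM to 10000 nM.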

Compound 4, half-maximal inhibitory concentration: 40000 nM
Compound 4: the middle estimate sits 80-fold (1.90 log units) below what was measured; measured number above the stated range.
By their numbers in this assay, from the lowest: compounds 3 and 1 (each within the scatter of the next); then compound 4. At a limit, above all of these: compound 2.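

Placing this ring with 2 hetero atoms directly on the saturated ring carbon gives only an at least 2.5-fold lower number from compound 2 to compound 4 (0.39 log units; beyond the scatter), so having such a ring at this position does not in itself bring strong inhibition. The same kind of ring, joined through an oxygen in compound 3, gave an at least 3300-fold lower number from compound 2 to compound 3 (3.52 log units; beyond the scatter), and compound 4 at 40000 nM remains far weaker than compound 3 at 30 nM. The true size of the new step stays unknown, as compound 2 carries a limit rather than a number: the limit of > 100000 nM in this assay, at which 1 of the 4 values shown sits.

Compound 3 and compound 4 differ both in how the ring is attached and in what the ring carries, so the compounds shown leave open which of these matters. They also leave open how a carboxylic acid or an amide in place of the amine on the ring would behave.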